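Aryl sulfonate series: methoxy removal and antiproliferative potency

The source may report more compounds than this note shows. Statements on the series, on what has been measured and on what is new or still open speak of the compounds shown alone.

Measured compounds in a functional assay on MCF7 cells (Homo sapiens) for antiproliferative activity, read by sulforhodamine B assay, with a stated time of 48 h; on this read-out lower numbers stand for stronger inhibition and higher numbers for weaker inhibition:
- compound 1, `COc1cccc(OS(=O)(=O)c2ccc(N3CCN(C)C3=O)cc2)c1`: 3000 nM
- compound 2, `COc1cc(OC)cc(OS(=O)(=O)c2ccc(N3CCN(C)C3=O)cc2)c1`: 230 nM
- compound 3, `CCN1CCN(c2ccc(S(=O)(=O)Oc3ccc(OC)c(OC)c3)cc2)C1=O`: 39100 nM

Compound 2 carries two methoxy groups on the sulfonate-bearing ring and gives the lowest number of the three. Removing one of them gives compound 1, and the change hydrogen in place of methoxy on an aromatic carbon produces a 13-fold higher number from compound 2 to compound 1 (1.12 log units; beyond the scatter). Compound 3 differs from compound 2 in more than one place; the difference between the two cores is not broken down here. Compound 3 stands highest of the three, with compound 1 nearest and compound 2 furthest.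

Compound 4, `CCN1CCN(c2ccc(S(=O)(=O)Oc3ccc(OC)cc3)cc2)C1=O`, is not yet measured. Relative to compound 3 the change is hydrogen in place of methoxy on an aromatic carbon. This is the same kind of change as that from compound 2 to compound 1, but not the same: in compound 2 the leaving methoxy is meta to a methoxy group, whereas in compound 3 it is ortho to a methoxy group; in both cases it is meta to a large group.

Within the data shown here, the single precedent indicates that losing a methoxy weakens inhibition. Compound 4 is therefore expected to give a higher number than compound 3, with the step estimated as a 2.0-fold higher number from compound 3 to compound 4 (0.31 log units; beyond the scatter), resting on a 13-fold higher number from compound 2 to compound 1 (1.12 log units; beyond the scatter) and on compound 3 already sitting at 39100 nM. Compound 4 is estimated at 80000 nM, within 20000 nM to 300000 nM, with a real chance that only a limit is reported.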

Compound 4, half-maximal inhibitory concentration: > 100000 nM
Compound 4: only a limit was reported; the forecaster's own chance of this, stated with the estimate: 40%; middle value at least 1.2-fold (0.09 log units) from the limit.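

In this assay compound 4 gives > 100000 nM, which is a limit of the assay and not a number: the limit of > 100000 nM in this assay, at which 1 of the 4 values shown sits.

Hydrogen in place of methoxy on an aromatic carbon gives an at least 2.5-fold higher number from compound 3 to compound 4 (0.40 log units; beyond the scatter), so the direction seen on the core of compound 2 also holds on the core of compound 3, here with the leaving methoxy ortho to a methoxy group. This shows that the sign of the change carries from one core to the other across these two pairs, but it does not show that the size carries, and two pairs do not make a rule for the series: the same change on two cores in this assay, a 13-fold higher number (1.12 log units; beyond the scatter) from compound 2 to compound 1 and an at least 2.5-fold higher number (0.40 log units; beyond the scatter) from compound 3 to compound 4; the limit leaves it open whether they differ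

The compounds shown leave open how the wide gap between compound 2 and compound 3 divides between the ethyl or methyl group on the core and the placing of the methoxy groups on the aromatic ring, as these two compounds differ in more than one place. They also leave open whether a hydroxy group, a fluorine atom or a longer chain such as ethoxy, put on that aromatic carbon in place of the methoxy, would follow the same direction in this assay.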